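Prenyl Extensions on a Pyridinone Core Against Pancreatic Cells

This account rests on a few compounds, and the source may have more. Where it says the series, first, only, none or still open, it means among the compounds named here.

Compound 1 `CC(C)=CCC1Cc2c(O)cc(=O)n(CCCO)c2CC1(C)C` gives 0% in a functional assay on PANC-1 cells (Homo sapiens) for inhibition, read by MTT assay, with a stated time of 24 h, tested at 10 uM; on this read-out lower numbers stand for less inhibition and higher numbers for more inhibition at the one concentration tested (going by the name of the read-out). Compound 2 `CC(C)=CCC/C(C)=C/CC1Cc2c(O)cc(=O)n(CCCO)c2CC1(C)C` differs from it by 3-methylbut-2-en-1-yl in place of hydrogen on a saturated chain carbon bound to a double-bonded chain carbon, a change that produced no change at the digits printed from compound 1 to compound 2 (within the scatter), and compound 2 reaches 0%. Compound 3 `CC(C)=CCOc1cc(=O)n(CCCO)c2c1CC(CC=C(C)C)C(C)(C)C2` carries a different change on the same core, (3-methylbut-2-en-1-yl in place of hydrogen on an oxygen on an aromatic ring), which gave a number 7.5 percentage points higher from compound 1 to compound 3 (within the scatter); in this assay compound 3 shows 7.5%. Compound 4 `CC(C)=CCC/C(C)=C/COc1cc(=O)n(CCCO)c2c1CC(CC=C(C)C)C(C)(C)C2` has not been measured. It differs from compound 3 by 3-methylbut-2-en-1-yl in place of hydrogen on a saturated chain carbon bound to a double-bonded chain carbon, the same change seen from compound 1 to compound 2, placed on the same kind of chain carbon, while the two cores differ by 3-methylbut-2-en-1-yl in place of hydrogen on an oxygen on an aromatic ring. Because the earlier step was no change at the digits printed from compound 1 to compound 2 (within the scatter), the step from compound 3 to compound 4 is expected to be no change at the digits printed from compound 3 to compound 4 (within the scatter). Compound 4 is therefore estimated at 7.5%, between 0% and 20%.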

Compound 4, a percentage reported as inhibition, at one concentration (the size of the read-out at that concentration, not a potency): 18.4%
Beside the measured number, compound 4's estimate is 10.9 percentage points below it, and the stated range covers the measured number.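

In this assay, extending the chain on the oxygen gave a number 10.9 percentage points higher from compound 3 to compound 4 (beyond the scatter), and the full 3,7-dimethylocta-2,6-dien-1-yl on that oxygen gave a number 18.4 percentage points higher from compound 1 to compound 4 (beyond the scatter). Set beside the earlier step, the same change cannot be told apart on the two cores: the same change on two cores in this assay, no change at the digits printed (within the scatter) from compound 1 to compound 2 and a number 10.9 percentage points higher (beyond the scatter) from compound 3 to compound 4, 10.9 percentage points apart, within the scatter of two such steps. This does not show that the change carries over with the same size, nor that the core alters its size, and it rests on a single pair of steps.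

The compounds shown leave open whether a still longer chain on the oxygen would raise the inhibition further. They also leave open what an amine or a carboxylic acid at the end of that chain would do.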